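Swapping a furanylmethylsulfanyl arm for fluorine on the amide side

The compounds below may be only part of what the source reports. "The series", "measured", "known", "first", "only" and "open" are said of these compounds alone.

The series rests on a shared core carrying a methanesulfonamide and a propanamide, varied only at one aromatic carbon. Compound 1 `CCCOc1cc(C(F)(F)F)ccc1CNC(=O)C(C)c1ccc(NS(C)(=O)=O)c(F)c1` gives 2 nM in an assay on CHO cells for antagonist activity at transient receptor potential cation channel subfamily V member 1 (Homo sapiens), read by FLIPR; a lower number here means a stronger inhibitor, a higher number a weaker inhibitor. Compound 2 `CC(C(=O)NCc1ccc(C(F)(F)F)cc1SCc1ccco1)c1ccc(NS(C)(=O)=O)c(F)c1` gives 3.2 nM in this assay. Among the compounds with values here, the one step between them, a 1.6-fold higher number from compound 1 to compound 2 (0.20 log units; within the scatter), puts compound 2 at the higher of the two numbers, with compound 1 its nearest neighbour, the pair sitting within the scatter of each other.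

Compound 3 `CC(C(=O)NCc1ccc(C(F)(F)F)cc1F)c1ccc(NS(C)(=O)=O)c(F)c1` is not yet measured. It differs from compound 2 by fluoro in place of ((furan-2-yl)methyl)sulfanyl on an aromatic carbon. Within the data shown here, only the step from compound 1 to compound 2 touches this position, and it showed that exchanging propoxy for the furanylmethylsulfanyl arm left the number essentially unchanged. Among the measured compounds shown here, no measured step shows what a single fluorine does at this aromatic carbon, so the guide is thin. The estimated step for compound 3 is a 3.8-fold higher number from compound 2 to compound 3 (0.57 log units; beyond the scatter), a larger change than the one already seen and toward a higher number, yet of moderate size. Compound 3 is therefore expected to give about 12 nM in this assay, plausibly between 3 nM and 50 nM.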

Compound 3, inhibition constant: 68.7 nM
Beside the measured number, compound 3's estimate is 5.7-fold (0.76 log units) below it; measured number outside the range, above it.
By their numbers in this assay, from the lowest: compounds 1 and 2 (each within the scatter of the next); then compound 3.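

In this assay this aromatic carbon turns out not to be indifferent to what it carries: propoxy and the ((furan-2-yl)methyl)sulfanyl arm lie within the scatter of each other, yet fluoro in place of the arm gives a 21-fold higher number from compound 2 to compound 3 (1.33 log units; beyond the scatter) and fluoro in place of propoxy gives a 34-fold higher number from compound 1 to compound 3 (1.54 log units; beyond the scatter) in the same assay. Among these three compounds, then, two quite different arms share the low numbers, while fluoro, with its 1 heavy atom, stands alone at the high end, so the earlier near-silent exchange did not mean that any group would be tolerated here. Nothing at hand gives a measured reason for this large rise with fluoro.

The compounds shown leave open whether the rise follows the loss of a chain or the presence of fluorine itself, a question that plain hydrogen or a methoxy group on this carbon would help to settle. On these data alone, it also remains open how far the low numbers extend to a longer chain such as butoxy, to an amine, or to a propylsulfanyl arm without the furan ring.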